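A few compounds are considered here, and "the series" means these few. Any claim that something is new, unique, unknown or untested is made for them only; others in the source may bear on it.

In an ADME assay on microsomes from liver (Rattus norvegicus), read by LC-MS, using NADPH, with a stated time of 10 min, tested at 0.5 uM (on this read-out higher numbers stand for a more stable compound and lower numbers for a less stable compound), compound 1 (`Cc1nc2cc(-c3ccc(OCc4ccccc4)cc3)nn2c(-c2cc(F)c3c(c2C)CCCO3)c1C(OC(C)(C)C)C(=O)O`) gives 79%, compound 2 (`Cc1nc2cc(-c3cccc(-c4ccccc4)c3)nn2c(-c2cc(F)c3c(c2C)CCCO3)c1[C@H](OC(C)(C)C)C(=O)O`) gives 96% and compound 3 (`Cc1nc2cc(-c3cccc(-c4ccccc4)c3)nn2c(-c2cc(F)c3c(c2C)CCCO3)c1C(OC(C)(C)C)C(=O)O`) gives 100%. Compound 2 therefore sits within the scatter of compound 3, while the value of compound 1 is clearly lower. Compound 4 (`Cc1ccccc1-c1cccc(-c2cc3nc(C)c([C@H](OC(C)(C)C)C(=O)O)c(-c4cc(F)c5c(c4C)CCCO5)n3n2)c1`) has methyl in place of hydrogen on an aromatic carbon, ortho to a large group, the phenyl becoming 2-methylphenyl: methyl in place of hydrogen on an aromatic carbon. Among the compounds with values here, the only measured step, a number 4 percentage points higher from compound 2 to compound 3 (within the scatter), concerns (the fact that one of compounds 2 and 3 is drawn with a defined configuration and the other without, at the place where they differ), so it is no direct test of this methyl. Within the data shown here, with no measured precedent for a shift, no change beyond the scatter is expected. The expected step is a number 3 percentage points lower from compound 2 to compound 4 (within the scatter). Compound 4 is estimated at 93%, with an expected range of 81% to 100%.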

Compound 4, percent of the compound remaining: 97%
Compound 4: the middle estimate sits 4 percentage points below what was measured; the measured number falls inside the stated range.
By their numbers in this assay, from the lowest: compound 1; then compounds 2, 4 and 3 (each within the scatter of the next).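

In this assay, the change from phenyl to 2-methylphenyl gives a number 1 percentage points higher from compound 2 to compound 4 (within the scatter). Within the data shown here, this is the first reading of a substituent at this place on the ring, and it shows that methyl is accepted there without a shift beyond the scatter, which the earlier step, a difference in drawn configuration only, could not show. Nothing at hand bears on a cause for this step. As far as these compounds go, whether another group at this place, such as an amine or a longer chain, would stay within the scatter remains open.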